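Adding a Bromine to the Phenyl Group of Compound 3

The source may hold more compounds than are shown below. What is called first, only, known or untested is meant among the compounds shown, and "the series" means these compounds.

The three measured compounds were all tested in a toxicity assay on MCF7 cells (Homo sapiens) for cytotoxicity, read by MTT assay; a higher number here means a weaker inhibitor of growth, a lower number a stronger inhibitor of growth:

compound 1, `C/C(=N\NC(N)=S)c1sc(-c2ccccc2)nc1C`: 26 ug/mL
compound 2, `C/C(=N\Nc1nc(-c2ccccc2)cs1)c1sc(C)nc1C`: > 100 ug/mL, a limit of the assay
compound 3, `C/C(=N\Nc1nc(-c2ccccc2)cs1)c1sc(-c2ccccc2)nc1C`: > 100 ug/mL, a limit of the assay

Compound 3 stands where a number is not known, only a limit. Compound 2 also reports a limit, not a number. Within the data shown here, the one step between compounds that differ in a single place, a step that the two limits leave unreadable from compound 2 to compound 3, is therefore of unknown size, and this is because of the limit of > 100 ug/mL in this assay, at which 2 of the 3 values shown sit.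

Compound 4, `C/C(=N\Nc1nc(-c2ccc(Br)cc2)cs1)c1sc(-c2ccccc2)nc1C`, has not been measured. It differs from compound 3 by bromo in place of hydrogen on an aromatic carbon. Among the measured compounds shown here, no measured step bears on such a change, and the only step that exists is unreadable. Compound 4 is therefore expected to behave much like compound 3, with a step of a number no higher from compound 3 to compound 4 (the limit leaves the size open) that is most likely not beyond the scatter, and probably again a limit rather than a number. The estimate for compound 4 is 100 ug/mL, within a range from 35 ug/mL to 300 ug/mL.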

Compound 4, concentration for 50% growth inhibition: 26.3 ug/mL
Estimate against measurement, compound 4: 3.8-fold (0.58 log units) above; measured number below the stated range.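

In this assay, bromo in place of hydrogen gives an at least 3.8-fold lower number from compound 3 to compound 4 (0.58 log units; beyond the scatter). This is the only step among these compounds that can be read, as the other one cannot. It shows that this position, on a six-membered aromatic ring of carbon only and para to a large group, is not indifferent: one heavy atom placed there is enough to move compound 4 off the limit of the assay and onto a real number.

On these data alone, whether chloro, methoxy or an amine at the same position would act as bromo does remains open, as does whether bromo would have the same effect on compound 2. The full size of the step also stays unknown because one end of it is a limit: the limit of > 100 ug/mL in this assay, at which 2 of the 4 values shown sit.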